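The source may hold more compounds than are shown below. What is called first, only, known or untested is meant among the compounds shown, and "the series" means these compounds.

Measured compounds in a functional assay on MDA-MB-231 cells (Homo sapiens) for antiproliferative activity, read by MTT assay, with a stated time of 24 h; a higher number here means a weaker inhibitor, a lower number a stronger inhibitor:
Compound 1, `CC(C)(C)c1ccc(C(CC(=O)O)NS(=O)(=O)c2ccccc2)cc1`, gives > 100000 nM, which is a limit of the assay rather than a number.
Compound 2, `CC(C)(C)c1ccc(C(CC(=O)O)NS(=O)(=O)c2ccc(C(F)(F)F)cc2)cc1`, gives 53700 nM.
Compound 3, `O=C(O)CC(NS(=O)(=O)c1ccccc1)c1ccc(Cl)cc1Cl`, gives 57800 nM.

Compound 2 differs from compound 1 by one change, (trifluoromethyl in place of hydrogen on an aromatic carbon). The step this made is an at least 1.8-fold lower number from compound 1 to compound 2 (0.27 log units; that floor lies within the scatter); its floor comes from the limit of > 100000 nM in this assay, at which 1 of the 3 values shown sits. Compound 3 and compound 2 give values within the scatter of each other. The difference between the cores of compound 1 and compound 3 is not broken down here.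

Compound 4, `O=C(O)CC(NS(=O)(=O)c1ccc(C(F)(F)F)cc1)c1ccc(Cl)cc1Cl`, is not yet measured. It differs from compound 3 by trifluoromethyl in place of hydrogen on an aromatic carbon, the same change as between compound 1 and compound 2. In this assay the expected step from compound 3 to compound 4 is a 1.9-fold lower number from compound 3 to compound 4 (0.28 log units; within the scatter), resting on the earlier step of an at least 1.8-fold lower number from compound 1 to compound 2 (0.27 log units; that floor lies within the scatter). For compound 4 the estimated value is 30000 nM, between 12000 nM and 75000 nM.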

Compound 4, half-maximal inhibitory concentration: 30400 nM
Beside the measured number, compound 4's estimate is 1.0-fold (0.01 log units) below it, within the range that was stated.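

In this assay, trifluoromethyl in place of hydrogen on an aromatic carbon gives a 1.9-fold lower number from compound 3 to compound 4 (0.28 log units; within the scatter). This step lies within the scatter, so on its own it does not show that the change carries a real effect from one core to the other, and the two cores cannot be said to respond either alike or differently: the same change on two cores in this assay, an at least 1.8-fold lower number (0.27 log units; that floor lies within the scatter) from compound 1 to compound 2 and a 1.9-fold lower number (0.28 log units; within the scatter) from compound 3 to compound 4; the limit leaves it open whether they differ. Compound 1 stands at a limit of the assay, not at a number: the limit of > 100000 nM in this assay, at which 1 of the 4 values shown sits.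

The compounds shown leave open whether another group in the same place on the ring, such as a nitrile or an amine, would give a step beyond the scatter. They also leave open how trifluoromethyl would behave on a third core.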